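The compounds below may be only part of what the source reports. "The series", "measured", "known", "first", "only" and "open" are said of these compounds alone.

Compound 1 `O=C(CCCCC1CCSS1)Nc1cccc(C(F)(F)F)c1`: 9.5%
Compound 2 `O=C(CCCCC1CCSS1)Nc1ccc(Cl)cn1`: 0.76%
Compound 3 `O=C(CCCCC(S)CCS)Nc1cccc(Cl)c1`: "not active" (no number reported)

All three compounds were tested in a functional assay on KB cells (Homo sapiens) for inhibition, read by MTT assay, with a stated time of 24 h, tested at 1 ug/mL; a lower number here means less inhibition of growth, a higher number more inhibition of growth at the concentration tested. Compound 1 gave 9.5%, and compound 2 gave 0.76%. These two values lie within the usual scatter of each other, and neither shows much inhibition of growth at the concentration tested. Compound 3 has no single number and was reported only as "not active" (no number reported).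

Compound 4 `Cc1cccc(NC(=O)CCCCC(S)CCS)c1` has not yet been measured. Its structure departs in one place from that of compound 3: methyl in place of chloro on an aromatic carbon. This is methyl in place of chloro on an aromatic carbon, meta to a large group. For the measured compounds named here, no measured pair in this small set shows what such an exchange does, so any expectation rests on thin ground. With compound 3 reported as "not active" (no number reported), no step beyond the scatter is expected in this assay, in either direction. A report of no activity would therefore come as no surprise. For compound 4 the estimated value is 3%, with an expected range from 0% to 12%.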

Compound 4, percent growth inhibition at one concentration: 3.31%
Beside the measured number, compound 4's estimate is 0.3 percentage points below it; the range from low to high includes it.
By their numbers in this assay, from the lowest: compounds 2, 4 and 1 (each within the scatter of the next).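

In this assay, for the compounds shown here, compound 3 stands as "not active" (no number reported) and compound 4 as 3.31% with no step between them that can be read. Going by these compounds, what methyl in place of chloro on the aromatic carbon does to inhibition of growth remains open across these compounds. No other measurement shown here bears on this result.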